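This account rests on a few compounds, and the source may have more. Where it says the series, first, only, none or still open, it means among the compounds named here.

Measured: compound 1 `CCc1ccc(C(=O)NC[C@H]2c3[nH]c4ccccc4c3C[C@H]3[C@H]4c5[nH]c6ccccc6c5C[C@@H]([C@H](C#N)N23)N4C)cc1` with 100 nM in a functional assay on HCT-116 cells (Homo sapiens) for cytotoxicity, read by MTT assay, with a stated time of 72 h; on this read-out lower numbers stand for stronger inhibition and higher numbers for weaker inhibition; compound 2 `CN1[C@@H]2c3[nH]c4ccccc4c3C[C@H]1[C@H](C#N)N1[C@@H](CNC(=O)c3cc4ccccc4o3)c3[nH]c4ccccc4c3C[C@@H]21` with 330 nM in this assay.

Among the compounds with values here, compound 2 holds the higher of the two numbers, its only neighbour being compound 1 through a 3.3-fold higher number from compound 1 to compound 2 (0.52 log units; beyond the scatter). Compound 3 `CN1[C@@H]2c3[nH]c4ccccc4c3C[C@H]1[C@H](C#N)N1[C@@H](CNC(=O)c3cc4ccccc4[nH]3)c3[nH]c4ccccc4c3C[C@@H]21` differs from compound 2 by 1H-indol-2-yl in place of 1-benzofuran-2-yl on a carbonyl carbon. Within the data shown here, no measured step covers this exchange; the single known step, a 3.3-fold higher number from compound 1 to compound 2 (0.52 log units; beyond the scatter), concerns another replacement on the same carbonyl carbon and gives no guidance here. For compound 3 the expected step is a 1.1-fold lower number from compound 2 to compound 3 (0.04 log units; within the scatter), within the scatter. The estimate for compound 3 in this assay is 300 nM, between 100 nM and 1000 nM.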

Compound 3, half-maximal inhibitory concentration: 880 nM
The estimate for compound 3 lay 2.9-fold (0.47 log units) below the measured number; low and high end bracket the measured number.
By their numbers in this assay, from the lowest: compound 1; then compound 2; then compound 3.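

In this assay the 1H-indol-2-yl group in place of 1-benzofuran-2-yl on the carbonyl carbon gives a 2.7-fold higher number from compound 2 to compound 3 (0.43 log units; beyond the scatter) and thus shows that two groups with the same heavy-atom count and ring types, differing in oxygen versus nitrogen, are not interchangeable here. Within the data shown here, replacing 4-ethylphenyl with 1H-indol-2-yl gives an 8.8-fold higher number from compound 1 to compound 3 (0.94 log units; beyond the scatter) and is the widest step so far, leaving 4-ethylphenyl with the lowest number of the three. Nothing measured accounts for these differences.

From the compounds shown here alone, it remains open how a longer chain in place of the ethyl group, or an amine on the phenyl ring, would compare with 4-ethylphenyl.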